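From Chloro to Fluoro: Estimating Compound 4

The source may report more compounds than this note shows. Statements on the series, on what has been measured and on what is new or still open speak of the compounds shown alone.

In a functional assay on the whole organism (strain NMRI) with Mus musculus as the target, with a stated time of 60 min, at a dose of 5 mg/kg by the intraperitoneal route (on this read-out higher numbers stand for a stronger effect at the one dose given and lower numbers for a weaker effect), compound 3 `Nc1nnc(Cc2ccc(Cl)cc2Oc2ccccc2Cl)o1` gives 125%, the second highest of three numbers. Compound 2 `CCSc1nnc(Cc2ccc(Cl)cc2Oc2ccccc2F)[nH]1` gives 126%, within the scatter of compound 3, while compound 1 `CSc1nnc(Cc2ccc(Cl)cc2Oc2ccccc2F)[nH]1` gives 110%, beyond it. For the measured compounds named here, the only one-place step measured is a number 16 percentage points higher from compound 1 to compound 2 (beyond the scatter), a change that lies elsewhere in the molecule. Compound 4 `Nc1nnc(Cc2ccc(Cl)cc2Oc2ccccc2F)o1` differs from compound 3 by fluoro in place of chloro on an aromatic carbon. Going by the values given here, no measured step bears on this halogen exchange; compounds 1 and 2, which carry fluoro, sit in the same region as compound 3 with chloro. The step of a number 5 percentage points lower from compound 3 to compound 4 (within the scatter) is therefore expected to stay within the scatter. Compound 4 is estimated at 120%, between 95% and 145%.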

Compound 4, a percentage reported as activity, at one dose (the size of the read-out at that dose, not a potency): 112%
Beside the measured number, compound 4's estimate is 8 percentage points above it, within the range that was stated.
By their numbers in this assay, from the lowest: compounds 1 and 4 (each within the scatter of the next); then compounds 3 and 2 (each within the scatter of the next).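

In this assay the halogen at this place, ortho to a large group, proves to count: the exchange of 2-chlorophenyl for 2-fluorophenyl gives a number 13 percentage points lower from compound 3 to compound 4 (beyond the scatter) and so is a modest but real change. With fluoro kept, exchanging the group on the saturated chain carbon gives a number 14 percentage points lower from compound 2 to compound 4 (beyond the scatter) in one pair, while it gives a number 2 percentage points higher from compound 1 to compound 4 (within the scatter) in the other. Nothing available explains these steps.

On these data alone, what bromo or a methoxy group would give at this place remains open.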